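The compounds below may be only part of what the source reports. "The series", "measured", "known", "first", "only" and "open" are said of these compounds alone.

The series is followed in an assay for binding affinity to retinoic acid receptor gamma (Homo sapiens); a lower number here means tighter binding, a higher number weaker binding. Compound 1 `CCCc1cc2c(cc1C(=O)c1ccc(C(=O)O)cc1)C(C)(C)CCC2(C)C` returns only the limit of the assay, > 1000 nM. Compound 2 `CC1(C)CCC(C)(C)c2cc(C(=O)c3ccc(C(=O)O)cc3)c(F)cc21` likewise returns only the limit, > 1000 nM. The step that the two limits leave unreadable from compound 1 to compound 2, fluoro in place of propyl on an aromatic carbon, therefore cannot be sized. Compound 3 `C=C(c1ccc(C(=O)O)cc1)c1cc2c(cc1C(C)C)C(C)(C)CCC2(C)C` also stands at the limit, > 1000 nM. Among the compounds with values here, all three values sit at the limit of > 1000 nM in this assay, at which 3 of the 3 values shown sit, so no step within the set is readable.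

Compound 4 `C=C(c1ccc(C(=O)O)cc1)c1cc2c(cc1Br)C(C)(C)CCC2(C)C` differs from compound 3 by bromo in place of isopropyl on an aromatic carbon, ortho to a large group, meta to a fused ring and para to a fused ring. Within the data shown here, the one measured step, a step that the two limits leave unreadable from compound 1 to compound 2, also puts a halogen where an alkyl group stood on an aromatic carbon, but its size is unreadable and gives no guide to direction or magnitude. With compound 3 at the limit, the step that the limit leaves unreadable from compound 3 to compound 4 is expected to stay within the scatter, with a real chance that only a limit is reported again. Compound 4 is estimated at 2500 nM, with a range from 300 nM to 20000 nM.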

Compound 4, dissociation constant: > 1000 nM
Compound 4: a limit, no number (the forecaster's own chance of this, stated with the estimate: 70%); the middle value lies beyond the limit too.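

No size can be read for bromo in place of isopropyl from compound 3 to compound 4 in this assay, as both compounds stand at a limit: the limit of > 1000 nM in this assay, at which 4 of the 4 values shown sit. On these data alone, how tightly compounds 1 to 4 bind remains open, as does whether either halogen-for-alkyl change alters binding.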